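The source may report more compounds than this note shows. Statements on the series, on what has been measured and on what is new or still open speak of the compounds shown alone.

Measured compounds in this set:
compound 1, `CN/C(=N\C1=NC(=O)C(=O)N1C(C)C)Nc1ccc(Cl)c(Cl)c1` — > 1 h
compound 2, `CC(C)N/C(=N\C1=NC(=O)C(=O)N1C(C)C)Nc1ccc(Cl)c(Cl)c1` — > 1 h

In an in vitro ADME assay on microsomes from liver (Mus musculus) for metabolic stability, read by LC-MS (on this read-out lower numbers stand for a shorter-lived compound and higher numbers for a longer-lived compound), compound 1 gives > 1 h, which is a limit of the assay and not a number. In this assay compound 2 gives > 1 h, again a limit rather than a number. The step that the two limits leave unreadable from compound 1 to compound 2 therefore cannot be read because of the limit of > 1 h in this assay, at which 2 of the 2 values shown sit. Compound 2 stands at that limit, and nothing in the two values shown separates it from compound 1.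

Compound 3, `CC(C)N1C(=O)C(=O)N=C1/N=C(/Nc1ccc(Cl)c(Cl)c1)NC(C)(C)C`, differs from compound 2 in one place: methyl in place of hydrogen on a saturated chain carbon bound to an amine nitrogen and two saturated chain carbons. Among the compounds with values here, the only measured step that bears on this change is the one from the methyl to the isopropyl group on the same amine nitrogen, and that step is unreadable, so no size and no direction can be taken from it. The working expectation for compound 3 is therefore a step that the limit leaves unreadable from compound 2 to compound 3 that stays within the scatter, and this assay is expected to report a limit again rather than a number. On that basis compound 3 is estimated at 1.5 h, within a range from 0.7 h to 4 h.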

Compound 3, half-life: > 1 h
Compound 3: no number, only a limit (the forecaster's own chance of this, stated with the estimate: 70%); the middle value lies beyond the limit too.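

Within the data shown here, no step among compound 1, compound 2 and compound 3 can be read in this assay because all three values are limits, not numbers: the limit of > 1 h in this assay, at which 3 of the 3 values shown sit.

The compounds shown leave open how the half-lives of the methyl, isopropyl and tert-butyl compounds compare beyond that limit, and whether these changes on the amine nitrogen make any difference.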